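A few compounds are considered here, and "the series" means these few. Any claim that something is new, unique, unknown or untested is made for them only; others in the source may bear on it.

In a functional assay on the whole organism (Hindlimb, strain albino) with Mus musculus as the target, in the maximal electroshock model, with a stated time of 0.5 h (a higher number here means that more compound is needed for the effect, a lower number that less compound is needed), compound 1 (`COc1ccc(C2CC(Nc3nc4ccc(C)cc4s3)=NN2C(C)=O)cc1`) gives 37.3 umol/kg and compound 2 (`CC(=O)N1N=C(Nc2nc3ccc(C)cc3s2)CC1c1ccc(O)cc1`) gives 50.2 umol/kg while compound 3 (`COc1ccc(C2CC(Nc3nc4ccc(C)cc4s3)=NN2C(C)=O)cc1O`) gives 73.9 umol/kg and so lies within the scatter of the other two. Compound 4 (`CC(=O)N1N=C(Nc2nc3ccc(C)cc3s2)CC1OC1=CC=C1`) differs from compound 3 at one place (a group of 5 heavy atoms (4 carbon, 1 oxygen; one four-membered non-aromatic ring of carbon only) in place of a group of 9 heavy atoms (7 carbon, 2 oxygen; one six-membered aromatic ring of carbon only), on a saturated ring carbon). The measured steps that bear on this are a 1.3-fold higher number from compound 1 to compound 2 (0.13 log units; within the scatter) and a 2.0-fold higher number from compound 1 to compound 3 (0.30 log units; within the scatter) and a 1.5-fold higher number from compound 2 to compound 3 (0.17 log units; within the scatter) and all of them stay within the scatter. Each keeps the six-membered aromatic ring, so none gives a direction for its loss, and no step beyond the scatter is expected. The estimate amounts to a 1.2-fold lower number from compound 3 to compound 4 (0.09 log units; within the scatter) in this assay and is expected to stay within the scatter. Compound 4 is expected at 60 umol/kg (estimated range 20 umol/kg to 170 umol/kg).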

Compound 4, dose for half-maximal effect: 160 umol/kg
Compound 4: the middle estimate sits 2.7-fold (0.43 log units) below what was measured, and the stated range covers the measured number.
By their numbers in this assay, from the lowest: compounds 1, 2 and 3 (each within the scatter of the next); then compound 4.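

On the saturated ring carbon, the earlier changes all kept the six-membered aromatic ring and stayed within the scatter in this assay. Within the data shown here, replacing that ring with the group carrying the four-membered ring gives the first steps beyond the scatter, all in the same direction: a 2.2-fold higher number from compound 3 to compound 4 (0.34 log units; beyond the scatter) and a 3.2-fold higher number from compound 2 to compound 4 (0.50 log units; beyond the scatter) and a 4.3-fold higher number from compound 1 to compound 4 (0.63 log units; beyond the scatter). Nothing available gives a reason for this shift. The compounds shown leave open whether the aromatic ring itself matters or only the group that replaced it. They also leave open how an amine or a longer alkyl chain would read at this carbon.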